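A few compounds are considered here, and "the series" means these few. Any claim that something is new, unique, unknown or untested is made for them only; others in the source may bear on it.

Among the measured compounds shown here, in a functional assay on A549 cells (Homo sapiens) for cytotoxicity, read by MTT assay, with a stated time of 72 h (on this read-out lower numbers stand for stronger inhibition and higher numbers for weaker inhibition), two compounds have numbers so far. Compound 1 `O=S(=O)(c1ccc(F)cc1)c1nc2ccccc2nc1N1CCCC1` gives 31100 nM, and compound 2 `Cc1ccc(S(=O)(=O)c2nc3ccccc3nc2N2CCC(O)CC2)cc1` gives 4020 nM. Compound 2 therefore holds the lower of the two numbers, and its gap to compound 1 lies beyond the usual scatter. For the measured compounds named here, no two measured compounds differ in one place only, so the data offer no single-change step to lean on.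

Compound 3 `O=S(=O)(c1ccc(F)cc1)c1nc2ccccc2nc1N1CCC(O)CC1` follows from compound 2 with fluoro in place of methyl on an aromatic carbon, para to a large group: fluoro in place of methyl on an aromatic carbon. The swap leaves the rest of compound 2 untouched, so compound 3 is expected to stay in the neighbourhood of compound 2 at 4020 nM. A slight lean toward weaker inhibition is expected, resting only on the higher number of compound 1 at 31100 nM, a weak guide since that compound also differs elsewhere. The expected change is a 1.4-fold higher number from compound 2 to compound 3 (0.14 log units; within the scatter), a small step upward that may not exceed the scatter. For compound 3 the estimated value is 5500 nM, with an expected range from 1800 nM to 16000 nM.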

Compound 3, half-maximal inhibitory concentration: 20200 nM
The estimate for compound 3 lay 3.7-fold (0.56 log units) below the measured number; measured number outside the range, above it.
By their numbers in this assay, from the lowest: compound 2; then compounds 3 and 1 (each within the scatter of the next).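

Among the compounds shown here, with 4-hydroxypiperidin-1-yl held fixed, the change from 4-methylphenyl to 4-fluorophenyl in this assay gives a 5.0-fold higher number from compound 2 to compound 3 (0.70 log units; beyond the scatter), the first single-place reading at this position, and it shows that swapping methyl for fluoro on this aromatic carbon, a change of one heavy atom, is enough to move the number beyond the scatter. For the compounds shown here, with 4-fluorophenyl held fixed, putting 4-hydroxypiperidin-1-yl in place of pyrrolidin-1-yl gives a 1.5-fold lower number from compound 1 to compound 3 (0.19 log units; within the scatter), so of the two single changes now readable, only the one at the methyl position exceeds the scatter, and the other does not separate its two compounds. Nothing available explains why the methyl-to-fluoro change has this size.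

The compounds shown leave open whether the lower number of compound 2 belongs to methyl alone or would also appear with ethyl, chloro or methoxy at the same place. They also leave open whether the methyl-to-fluoro step would keep its size with pyrrolidin-1-yl or a morpholine in place of 4-hydroxypiperidin-1-yl.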